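Predicting a halogenated anilide on a weakly active core

The source may report more compounds than this note shows. Statements on the series, on what has been measured and on what is new or still open speak of the compounds shown alone.

Compound 1 `CCOC1=C(/C(C)=N/OCC(=O)Nc2ccccc2)N(C)S(=O)(=O)c2ccccc21` gives in a functional assay on THP-1 cells (Homo sapiens) for inhibition, read by ELISA, with stated times of 2 h and 48 h (on this read-out higher numbers stand for weaker inhibition and lower numbers for stronger inhibition), only a limit, > 20000 nM.
Compound 2 `CCOC1=C(/C(C)=N/OCC(=O)Nc2ccc(C(F)(F)F)cc2)N(C)S(=O)(=O)c2ccccc21` gives in this assay 16700 nM.
Compound 3 `C/C(=N\OCC(=O)Nc1ccccc1)C1=C(O)c2ccccc2S(=O)(=O)N1C` gives in this assay only a limit, > 20000 nM.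

From the compounds shown here alone, compound 3 thus sits at the limit (the limit of > 20000 nM in this assay, at which 2 of the 3 values shown sit), so its true potency is unknown beyond being weak. Compound 4 `C/C(=N\OCC(=O)Nc1ccc(F)c(Cl)c1)C1=C(O)c2ccccc2S(=O)(=O)N1C` differs from it by 3-chloro-4-fluorophenyl in place of phenyl on an amide-type nitrogen. The nearest measured step is an at least 1.1-fold lower number from compound 1 to compound 2 (0.07 log units; that floor lies within the scatter), a change on the same anilide ring that stayed within the scatter; the step that the two limits leave unreadable from compound 1 to compound 3 gives no further guidance. Adding two halogens to the ring is therefore expected to leave inhibition in this assay roughly unchanged or slightly stronger, so compound 4 is estimated at 15000 nM, within 5000 nM to 40000 nM, an expected step of an at least 1.3-fold lower number from compound 3 to compound 4 (0.12 log units; that floor lies within the scatter).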

Compound 4, half-maximal inhibitory concentration: > 20000 nM
Compound 4: a limit, no number; the forecaster's own chance of this, stated with the estimate: 55%; middle value at least 1.3-fold (0.12 log units) away from the limit.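

Compound 3 and compound 4 both give only a limit in this assay, so no step can be read between them: the limit of > 20000 nM in this assay, at which 3 of the 4 values shown sit.

The compounds shown leave open how strongly either one truly inhibits, and whether 3-chloro-4-fluorophenyl in place of phenyl changes inhibition at all.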